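Fluoro for methoxy on the sulfonyl-linked aryl ring

The compounds below may be only part of what the source reports. "The series", "measured", "known", "first", "only" and "open" are said of these compounds alone.

Measured compounds:
Compound 1, `CN(C)CC1CCCc2cc(S(=O)(=O)c3ccccc3)ccc21`, 0.0631 nM
Compound 2, `NC[C@@H]1CCCc2cc(S(=O)(=O)c3cccc(O)c3)ccc21`, 0.251 nM
Compound 3, `COc1cccc(S(=O)(=O)c2ccc3c(c2)CCC[C@H]3CN)c1`, 0.398 nM

In an assay on isolated protein for displacement of a labelled ligand from 5-hydroxytryptamine receptor 6 (Homo sapiens) (a higher number here means a weaker inhibitor, a lower number a stronger inhibitor), compound 3 gives 0.398 nM, the highest of the three numbers. Its nearest neighbour is compound 2, which gives 0.251 nM, and the step of a 1.6-fold higher number from compound 2 to compound 3 (0.20 log units; within the scatter) lies within the scatter. Compound 1 gives 0.0631 nM, a lower number that stands beyond the scatter from compound 3, but compound 1 differs in more than one place, so no single step can be read from it.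

Compound 4, `NC[C@@H]1CCCc2cc(S(=O)(=O)c3cccc(F)c3)ccc21`, has not been measured. It differs from compound 3 by fluoro in place of methoxy on an aromatic carbon. Among the compounds with values here, only the step from compound 2 to compound 3 bears on a change at this position, and it was within the scatter, so no clear movement is expected from a second small change there. The step of a 1.2-fold lower number from compound 3 to compound 4 (0.09 log units; within the scatter) is therefore expected to stay within the scatter. Compound 4 is estimated at 0.32 nM, with a range from 0.1 nM to 1 nM.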

Compound 4, inhibition constant: 0.0794 nM
Estimate against measurement, compound 4: 4.0-fold (0.61 log units) above, and the stated range ends above it.
By their numbers in this assay, from the lowest: compounds 1 and 4 (each within the scatter of the next); then compounds 2 and 3 (each within the scatter of the next).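

In this assay, the fluoro group shows that this position can move the number: replacing methoxy gives a 5.0-fold lower number from compound 3 to compound 4 (0.70 log units; beyond the scatter), and replacing hydroxy gives a 3.2-fold lower number from compound 2 to compound 4 (0.50 log units; beyond the scatter). The earlier exchange of hydroxy for methoxy stayed within the scatter, so the two oxygen-linked groups gave no sign that a change here could matter, whereas both steps to fluoro lie beyond the scatter. Nothing in the data shown explains this shift.

On these data alone, it remains open whether the lower number belongs to fluoro itself or follows from losing the oxygen-linked group, a question that chloro, trifluoromethyl or plain hydrogen at this place would help to settle. As far as these compounds go, it is also open whether fluoro would act in the same way alongside the dimethylamino group of compound 1.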